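Trifluoromethyl in place of chloro: compound 1 to compound 3

The source may hold more compounds than are shown below. What is called first, only, known or untested is meant among the compounds shown, and "the series" means these compounds.

Measured in a functional assay on HepG2 cells (Homo sapiens) for cytotoxicity, with a stated time of 24 h; on this read-out lower numbers stand for stronger inhibition and higher numbers for weaker inhibition:
Compound 1 `COc1cc(Cl)ccc1C(=O)Nc1ccc(Cl)cc1O` (7340 nM)
Compound 2 `COc1cc(Cl)ccc1C(=O)Nc1cc(Br)ccc1O` (5630 nM)

The values of compound 1 and compound 2 lie within the scatter of each other, so compound 1 holds no separate place on these numbers. Compound 3 `COc1cc(Cl)ccc1C(=O)Nc1ccc(C(F)(F)F)cc1O` differs from compound 1 at one place: trifluoromethyl in place of chloro on an aromatic carbon. It has trifluoromethyl in place of chloro on an aromatic carbon, meta to a hydroxy group and para to a large group. For the measured compounds named here, no measured pair here shows this change. The step expected in this assay is a 1.2-fold lower number from compound 1 to compound 3 (0.09 log units; within the scatter), none beyond the scatter. For compound 3 the estimated value is 6000 nM, with an expected range of 2500 nM to 14000 nM.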

Compound 3, half-maximal inhibitory concentration: 3900 nM
Compound 3: middle estimate off by 1.5-fold (0.19 log units), on the high side; the measured number falls inside the stated range.
By their numbers in this assay, from the lowest: compounds 3, 2 and 1 (each within the scatter of the next).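

In this assay, for the compounds shown here, trifluoromethyl in place of chloro on this aromatic carbon gives a 1.9-fold lower number from compound 1 to compound 3 (0.27 log units; within the scatter) and is the first measured step at this position. The position, meta to a hydroxy group and para to a large group, therefore takes trifluoromethyl without a shift beyond the scatter. Nothing available bears on why the numbers fall as they do.

The compounds shown leave open whether an amine, a nitrile or a carboxylic acid at this position would give a step beyond the scatter. They also leave open whether the same change would give a similar step on another assay.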